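This account rests on a few compounds, and the source may have more. Where it says the series, first, only, none or still open, it means among the compounds named here.

Working notes on the series. Compound 1 `C#CCN(C)CCCOc1ccc2c(c1)OCCC2=O` gives 32.1% in an ADME assay on BTI cells for inhibition of Amine oxidase [flavin-containing] A (Homo sapiens), read by fluorescence and Amplex Red, with a stated time of 15 min, tested at 100 uM; a lower number here means less inhibition, a higher number more inhibition at the concentration tested (going by the name of the read-out). Compound 2 `C#CCN(C)CCCCCOc1ccc2c(c1)OCCC2=O`, which differs from it by 2-(methyl(propargyl)amino)ethyl in place of methyl(propargyl)amino on a saturated chain carbon, three bonds along the chain from an oxygen on an aromatic ring, gives 6.04% in this assay; the step of a number 26.1 percentage points lower from compound 1 to compound 2 (beyond the scatter) is the only one measured so far. Among the measured compounds shown here, compound 2 thus stands lowest of the two numbers, with compound 1 as its only neighbour.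

Compound 3 `C#CCN(C)CCCCCCCCOc1ccc2c(c1)OCCC2=O` is not yet measured. It differs from compound 2 by 3-(methyl(propargyl)amino)propyl in place of methyl(propargyl)amino on a saturated chain carbon, five bonds along the chain from an oxygen on an aromatic ring. For the measured compounds named here, the one step that bears on this is the lengthening of the same chain from compound 1 to compound 2, which was modest and downward. A further lengthening is therefore expected to move inhibition in this assay little if at all, since compound 2 already sits near the bottom of the read-out; the step of a number 3 percentage points lower from compound 2 to compound 3 (within the scatter) is expected to lie within the scatter. Compound 3 is estimated at 3%, in the range -10% to 16%.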

Compound 3, a percentage reported as inhibition, at one concentration (the size of the read-out at that concentration, not a potency): 28.7%
Compound 3: the middle estimate sits 25.7 percentage points below what was measured; the whole stated range lies below it.
By their numbers in this assay, from the lowest: compound 2; then compounds 3 and 1 (each within the scatter of the next).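

In this assay the change to 3-(methyl(propargyl)amino)propyl at this place gives a number 22.7 percentage points higher from compound 2 to compound 3 (beyond the scatter), so the earlier step of a number 26.1 percentage points lower from compound 1 to compound 2 (beyond the scatter) does not extend into a steady fall with chain length at this position. Compound 1 at 32.1% and compound 3 at 28.7% lie within the scatter of each other, leaving compound 2 as the only one of the three set apart, with both its steps beyond the scatter. Nothing available on these compounds accounts for this dip and recovery.

Still open, on these data alone, is whether the intermediate chains on either side of compound 2, or a chain longer than that of compound 3, would follow the same course. As far as these compounds go, it is equally open whether the course would hold with a dimethylamino group in place of methyl(propargyl)amino at the chain end.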